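Chloro on the triazole phenyl of a limit compound

A few compounds are considered here, and "the series" means these few. Any claim that something is new, unique, unknown or untested is made for them only; others in the source may bear on it.

Measured compounds in a functional assay on SW480 cells (Homo sapiens) for cytotoxicity, read by MTT assay, with a stated time of 4 days; on this read-out higher numbers stand for weaker inhibition and lower numbers for stronger inhibition:
compound 1 `Cc1c(O)ccc2c1[C@H](Cn1cc(-c3ccccc3)nn1)[C@@]13CC(=O)[C@@](C)(CC[C@@H]21)C3` gives > 20000 nM
compound 2 `Cc1ccc(S(=O)(=O)Oc2ccc3c(c2C)[C@H](Cn2cc(-c4ccccc4)nn2)[C@@]24CC(=O)[C@@](C)(CC[C@@H]32)C4)cc1` gives > 20000 nM
compound 3 `C=C1C(=O)[C@]23C[C@@]1(O)CC[C@H]2c1ccc(OS(=O)(=O)c2ccc(C)cc2)c(C)c1[C@@H]3Cn1cc(-c2ccc(Cl)cc2)nn1` gives 2390 nM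

The value of compound 1 in this assay is a limit of the assay, not a number. The value of compound 2 is likewise a limit. Compound 1 therefore stands at the limit of > 20000 nM in this assay, at which 2 of the 3 values shown sit, and nothing shown places it any more precisely. Compound 3 gives a number within the measured range; it differs from compound 2 in several places at once, so the two values show only that one is a limit and the other a number.

Among the compounds with values here, the single measured step is a step that the two limits leave unreadable from compound 1 to compound 2, and it says nothing usable here, as both ends are limits.

Compound 4 `Cc1c(O)ccc2c1[C@H](Cn1cc(-c3ccc(Cl)cc3)nn1)[C@@]13CC(=O)[C@@](C)(CC[C@@H]21)C3` differs from compound 1 by chloro in place of hydrogen on an aromatic carbon. Within the data shown here, no measured step isolates this change. Among the measured compounds shown here, compound 3 is the only measured compound carrying 4-chlorophenyl and gives 2390 nM, but its other differences keep that from reading as a clean step.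

Compound 4 is therefore expected to move by about an at least 1.3-fold lower number from compound 1 to compound 4 (0.12 log units; that floor lies within the scatter), with a fair chance of remaining at a limit. The estimate for compound 4 is 15000 nM, within a range from 4000 nM to 40000 nM.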

Compound 4, half-maximal inhibitory concentration: > 20000 nM
Compound 4 ended at the assay's limit; the forecaster's own chance of this, stated with the estimate: 55%; middle value at least 1.3-fold (0.12 log units) away from the limit.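

In this assay compound 4 gives > 20000 nM, a limit of the assay and not a number. Compound 1 also sits at a limit, and no step can be read between compound 1 and compound 4. The compounds shown leave open which of the several differences between compound 2 and compound 3 goes with the measured number of compound 3.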